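Swapping a Carbamate for a Sulfonamide on a Shared Core

This account rests on a few compounds, and the source may have more. Where it says the series, first, only, none or still open, it means among the compounds named here.

Of the compounds shown here, two built on the same core have been measured in a functional assay (aorta) for antagonist activity, with Oryctolagus cuniculus as the target; on this read-out higher numbers stand for weaker inhibition and lower numbers for stronger inhibition. Compound 1 `CCCCc1ccc(CN(Cc2ccccc2)S(=O)(=O)c2ccccc2)c(=O)n1Cc1ccc(-c2ccccc2-c2nn[nH]n2)cc1` carries a benzyl(phenylsulfonyl)amino group on the chain carbon attached to the core, and in this assay compound 1 gives 20 nM. Compound 2 `CCCCc1ccc(CNC(=O)OC(C)(C)C)c(=O)n1Cc1ccc(-c2ccccc2-c2nn[nH]n2)cc1` carries a (tert-butoxycarbonyl)amino group at that position, and compound 2 gives 10 nM. Compound 2 thus shows the lower of the two numbers, yet its gap to compound 1 lies within the usual scatter, so neither can be called the more potent one.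

Compound 3 `CCCCc1ccc(CN(CC)S(C)(=O)=O)c(=O)n1Cc1ccc(-c2ccccc2-c2nn[nH]n2)cc1` has not yet been measured. It differs from compound 2 in one place: ethyl(methylsulfonyl)amino in place of (tert-butoxycarbonyl)amino on a saturated chain carbon bound to an aromatic carbon. Among the measured compounds shown here, the carbamate is replaced by a sulfonamide bearing an ethyl group, so the single hydrogen-bond donor of compound 2 is lost while the count of acceptors stays the same. Compound 1, which also carries a sulfonamide at this position, gives 20 nM, close to compound 2.

On this basis, the step of a 3.0-fold higher number from compound 2 to compound 3 (0.48 log units; beyond the scatter) is expected to be small, toward a slightly higher number, and hardly beyond the scatter. Compound 3 is therefore estimated at 30 nM, with a likely range from 8 nM to 120 nM.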

Compound 3, half-maximal inhibitory concentration: 2 nM
Compound 3: the middle estimate sits 15-fold (1.18 log units) above what was measured, outside the stated range (below it).
By their numbers in this assay, from the lowest: compound 3; then compounds 2 and 1 (each within the scatter of the next).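

At this position on the saturated chain carbon, a group with 0 hydrogen-bond donors can give a clearly stronger result than the (tert-butoxycarbonyl)amino group with its single donor: in this assay the change to ethyl(methylsulfonyl)amino gives a 5.0-fold lower number from compound 2 to compound 3 (0.70 log units; beyond the scatter) and so moves beyond the scatter, which the near-equal earlier pair did not do. A sulfonamide at this position does not by itself fix the number, since compound 1 with benzyl(phenylsulfonyl)amino gives 20 nM while compound 3 with ethyl(methylsulfonyl)amino gives 2 nM on the same core. Nothing available here accounts for the size or direction of this change.

The step from the carbamate swaps the linking group and adds the ethyl group in one move, so the compounds shown cannot separate the two, and a plain (methylsulfonyl)amino group at this position would be needed to tell them apart. As far as these compounds go, it also remains open how far the low number holds when the ethyl group gives way to a longer chain such as propyl, or when the whole group gives way to a free amine.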